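From Unsubstituted Phenyl Amide to a Methoxypyridinyl Analogue

The source may report more compounds than this note shows. Statements on the series, on what has been measured and on what is new or still open speak of the compounds shown alone.

Compound 1, `O=C(Nc1ccccc1)c1csc(Cc2c(Cl)cccc2Cl)n1`, is the parent of this small set. In an assay on CHO cells, read by calcium flux (a higher number here means a weaker inhibitor, a lower number a stronger inhibitor), compound 1 gives only a limit, > 4000 nM, which is where it stands among the values shown (the limit of > 4000 nM in this assay, at which 1 of the 3 values shown sits). Compound 2, `O=C(Nc1ccc(C(F)(F)F)cc1)c1csc(Cc2c(Cl)cccc2Cl)n1`, gives 88 nM in this assay, and compound 3, `O=C(Nc1ccc(C(F)(F)C(F)(F)F)cc1)c1csc(Cc2c(Cl)cccc2Cl)n1`, gives 350 nM. Both changes to the phenyl on the amide nitrogen lowered the number: an at least 45-fold lower number from compound 1 to compound 2 (1.65 log units; beyond the scatter), and an at least 11-fold lower number from compound 1 to compound 3 (1.05 log units; beyond the scatter). Between the two fluorinated analogues the difference is smaller: a 4.0-fold higher number from compound 2 to compound 3 (0.60 log units; beyond the scatter).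

Compound 4, `COc1ccc(NC(=O)c2csc(Cc3c(Cl)cccc3Cl)n2)cn1`, is not yet measured. It differs from compound 1 by 6-methoxypyridin-3-yl in place of phenyl on an amide-type nitrogen. Among the measured compounds shown here, no measured step introduces a methoxy group or a ring nitrogen at this position, so the two large steps bear on it only in that they alter the same ring and both lowered the number. The account therefore expects a smaller step downward, an at least 2.6-fold lower number from compound 1 to compound 4 (0.42 log units; beyond the scatter), and estimates compound 4 at 1500 nM in this assay, within a range from 300 nM to 6000 nM.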

Compound 4, half-maximal inhibitory concentration: > 4000 nM
Compound 4 ended at the assay's limit (the forecaster's own chance of this, stated with the estimate: 35%); middle value at least 2.6-fold (0.42 log units) away from the limit.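

In this assay, compound 1 and compound 4 both end at a limit, so no step between them can be read: the limit of > 4000 nM in this assay, at which 2 of the 4 values shown sit.

The compounds shown leave open how far either compound lies beyond that limit, and whether 6-methoxypyridin-3-yl in place of phenyl changes the number at all.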